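Cyclopropylmethoxy to isopropoxy: expected cytotoxicity step

This account rests on a few compounds, and the source may have more. Where it says the series, first, only, none or still open, it means among the compounds named here.

In an ADME assay on Vero cells (Chlorocebus sabaeus) for cytotoxicity, read by resazurin assay, with a stated time of 24 h (on this read-out lower numbers stand for higher toxicity in this test and higher numbers for lower toxicity in this test), compound 1 `CCCCCCO[C@@H]1C=CC(=O)[C@@H](COC(=O)C(C)(C)C)O1` gives 4800 nM, while compound 2 `CC(C)(C)C(=O)OC[C@H]1O[C@H](OCC2CC2)C=CC1=O` gives 77200 nM, the higher number of the pair. Compound 3 `CC(C)O[C@@H]1C=CC(=O)[C@@H](COC(=O)C(C)(C)C)O1` carries isopropyl in place of cyclopropylmethyl on an oxygen on a saturated carbon. For the measured compounds named here, the only measured step bearing on this is a 16-fold higher number from compound 1 to compound 2 (1.21 log units; beyond the scatter), a large one, but it exchanges pentyl for cyclopropyl. The present exchange, cyclopropylmethoxy to isopropoxy, involves no such long chain, so no step beyond the scatter is expected in this assay. The estimated step is a 1.0-fold lower number from compound 2 to compound 3 (0.01 log units; within the scatter). For compound 3 the expected value is 75000 nM, with an estimated range from 30000 nM to 160000 nM.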

Compound 3, half-maximal cytotoxic concentration: 12500 nM
Estimate against measurement, compound 3: 6.0-fold (0.78 log units) above, outside the stated range (below it).
By their numbers in this assay, from the lowest: compound 1; then compound 3; then compound 2.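

In this assay, the group on this oxygen matters even with no long chain involved: isopropyl in place of cyclopropylmethyl gives a 6.2-fold lower number from compound 2 to compound 3 (0.79 log units; beyond the scatter), while isopropyl in place of hexyl gives a 2.6-fold higher number from compound 1 to compound 3 (0.42 log units; beyond the scatter). Group size alone does not order these three compounds, since isopropyl, the smallest group, stands between hexyl and cyclopropylmethyl. No measurement at hand accounts for these steps. Where a cyclobutylmethyl group or a chain ending in an amine would stand at this position remains open, as does whether this order holds in other cell types.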